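A Chlorophenyl Swap on the Shared Core

This account rests on a few compounds, and the source may have more. Where it says the series, first, only, none or still open, it means among the compounds named here.

Compound 1 is `COc1ccccc1-c1ncnn1-c1cc(OC)c(OC)c(OC)c1`. In a functional assay on Jurkat cells (Homo sapiens) for antiproliferative activity, read by MTT assay, with a stated time of 72 h (a lower number here means a stronger inhibitor, a higher number a weaker inhibitor), compound 1 gives > 10000 nM, which is a limit of the assay and not a number.
Compound 2 is `COc1cc(-c2ncnn2-c2cccc(N)c2)cc(OC)c1OC`. In this assay compound 2 gives > 10000 nM, again a limit rather than a number.
Compound 3 is `COc1cc(-n2ncnc2-c2cccc(Cl)c2)cc(OC)c1OC`. In this assay compound 3 gives > 10000 nM, also only a limit.

Compound 2 therefore stands at the edge of what this assay can report: its true value is somewhere beyond the limit, and the two other measured compounds sit at the same limit, so no ordering among the three can be read. Compound 4 is `COc1cc(-c2ncnn2-c2ccc(Cl)cc2)cc(OC)c1OC`, and it differs from compound 2 in one place: 4-chlorophenyl in place of 3-aminophenyl on an aromatic nitrogen.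

Going by the values given here, the only measured step between compounds that differ in one place is a step that the two limits leave unreadable from compound 1 to compound 3, and because the limit of > 10000 nM in this assay, at which 3 of the 3 values shown sit, its size cannot be read. So no measured step tells how large a change in this assay to expect from swapping one phenyl for another on this core, in either direction.

With three compounds all at the limit, compound 4 is expected to give 15000 nM, with a range from 5000 nM to 60000 nM. The expected step, a step that the limit leaves unreadable from compound 2 to compound 4, is not one that the data can make visible beyond the scatter.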

Compound 4, half-maximal inhibitory concentration: > 10000 nM
Compound 4: a limit, no number; the forecaster's own chance of this, stated with the estimate: 80%; the middle value does not contradict the limit.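

Compound 2 and compound 4 each give only a limit and not a number, so no step can be read between them, because both sit at the same edge of what can be reported: the limit of > 10000 nM in this assay, at which 4 of the 4 values shown sit.

The compounds shown leave open how far beyond that limit each one truly lies in this assay and which phenyl swap on the shared core, if any, would give a readable number.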